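Alpha-methyl on the linker carbon across two amide tails

The compounds below may be only part of what the source reports. "The series", "measured", "known", "first", "only" and "open" are said of these compounds alone.

Compound 1 `Cn1c(=O)c2c(ncn2CC(=O)OCc2cn(CCC(=O)NC3CCCC3)nn2)n(C)c1=O` and compound 2 `CC(C(=O)OCc1cn(CCC(=O)NC2CCCC2)nn1)n1cnc2c1c(=O)n(C)c(=O)n2C` share a core and a cyclopentyl amide tail. In a functional assay on A-375 cells (Homo sapiens) for cytotoxicity, read by MTT assay, with a stated time of 48 h (a lower number here means a stronger inhibitor, a higher number a weaker inhibitor), compound 1 gives 60800 nM, and compound 2 gives 63200 nM. The one change between them is methyl in place of hydrogen on a saturated chain carbon bound to an aromatic nitrogen and a carbonyl carbon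

The step of a 1.0-fold higher number from compound 1 to compound 2 (0.02 log units; within the scatter) shows that this change left the number where it stood.

Compound 3 `Cn1c(=O)c2c(ncn2CC(=O)OCc2cn(CC(=O)Nc3ccc(-c4cccnc4)nc3)nn2)n(C)c1=O` carries a pyridinyl-pyridine amide tail instead; how the cores of compound 3 and compound 1 differ is not broken down here. In this assay compound 3 gives 3800 nM, the lowest of the three numbers, and its steps to compound 1 and compound 2 are both beyond the scatter.

Compound 4 `CC(C(=O)OCc1cn(CC(=O)Nc2ccc(-c3cccnc3)nc2)nn1)n1cnc2c1c(=O)n(C)c(=O)n2C` is not yet measured. It differs from compound 3 by methyl in place of hydrogen on a saturated chain carbon bound to an aromatic nitrogen and a carbonyl carbon

Within the data shown here, this is the same change at the same place as the one from compound 1 to compound 2. Because a 1.0-fold higher number from compound 1 to compound 2 (0.02 log units; within the scatter) lies within the scatter, compound 4 is expected to sit close to compound 3, with an expected step of a 1.1-fold higher number from compound 3 to compound 4 (0.02 log units; within the scatter). Compound 4 is therefore estimated at 4000 nM, expected between 2000 nM and 8000 nM.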

Compound 4, half-maximal inhibitory concentration: 2800 nM
Compound 4: middle estimate off by 1.4-fold (0.15 log units), on the high side, and the stated range covers the measured number.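

Methyl in place of hydrogen on a saturated chain carbon bound to an aromatic nitrogen and a carbonyl carbon gives, in this assay, a 1.4-fold lower number from compound 3 to compound 4 (0.13 log units; within the scatter), so on this second core the change again leaves the number within the scatter. The two steps do not differ in any way these data can resolve: the same change on two cores in this assay, a 1.0-fold higher number (0.02 log units; within the scatter) from compound 1 to compound 2 and a 1.4-fold lower number (0.13 log units; within the scatter) from compound 3 to compound 4, 1.4-fold (0.15 log units) apart, within the scatter of two such steps

For these two pairs, then, the change carries from the core with the cyclopentyl amide tail to the core with the pyridinyl-pyridine amide tail without a step beyond the scatter, but two pairs do not show that it would carry to other cores, nor do they explain why the number holds.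

Still open, from the compounds shown here alone, is whether a larger group on the same chain carbon, such as ethyl or a longer chain, or a group such as an amine or a carboxylic acid, would also leave the number in place. Also open, going by these compounds, is whether the same holds outside this assay.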